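A few compounds are considered here, and "the series" means these few. Any claim that something is new, unique, unknown or untested is made for them only; others in the source may bear on it.

Measured so far in a functional assay on SW480 cells (Homo sapiens) for cytotoxicity, read by MTT assay, with a stated time of 24 h; on this read-out lower numbers stand for stronger inhibition and higher numbers for weaker inhibition:

compound 1 `C=CC1=C(C(=O)NCC(C)C)C(c2ccc(F)cc2)OC1` — > 100000 nM
compound 2 `C=CC1=C(C(=O)NCC(C)C)C(c2ccc(Cl)c(Cl)c2)OC1` — > 100000 nM
compound 3 `C=CC1=C(C(=O)NC(C)(C)C)C(c2ccc(Cl)c(Cl)c2)OC1` — > 100000 nM

In this assay compound 1 gives > 100000 nM, which is a limit of the assay and not a number. Compound 2 gives > 100000 nM in this assay, again a limit. Compound 3 gives > 100000 nM in this assay, also a limit. Among the compounds with values here, the whole picture so far is the limit of > 100000 nM in this assay, at which 3 of the 3 values shown sit, so no compound can be ordered against any other.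

Compound 2 and compound 3 differ by tert-butyl in place of isobutyl on an amide-type nitrogen. The step between them in this assay is a step that the two limits leave unreadable from compound 2 to compound 3; with both values sitting at the limit, its size cannot be read. The difference between the core of compound 1 and the core of compound 2 is not broken down here.

Compound 4 `C=CC1=C(C(=O)NC(C)(C)C)C(c2ccc(F)cc2)OC1` has not yet been measured. It differs from compound 1 by tert-butyl in place of isobutyl on an amide-type nitrogen, and the place is the same word for word as in the pair of compound 2 and compound 3, so this is the same change. Within the data shown here, since the one measured instance of this change, a step that the two limits leave unreadable from compound 2 to compound 3, is unreadable, and since compound 1 itself sits at the limit, there is no basis for expecting compound 4 to move off it. The expected step from compound 1 to compound 4 in this assay is a step that the limit leaves unreadable from compound 1 to compound 4, which is only nominal. Compound 4 is therefore expected to give about 150000 nM in this assay, with a range from 50000 nM to 500000 nM, and most likely only a limit will be reported.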

Compound 4, half-maximal inhibitory concentration: > 100000 nM
Compound 4: only a limit was reported; the forecaster's own chance of this, stated with the estimate: 85%; the middle value does not contradict the limit.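

In this assay compound 4 gives > 100000 nM, a limit and not a number. No new step can be read between compound 1 and compound 4, and the series stays at a single limit: the limit of > 100000 nM in this assay, at which 4 of the 4 values shown sit.

The compounds shown leave open whether tert-butyl in place of isobutyl on an amide-type nitrogen, or the difference between the core of compound 1 and the core of compound 2, changes this read-out at all.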